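Working notes on compound 4 in the cytotoxicity series

A few compounds are considered here, and "the series" means these few. Any claim that something is new, unique, unknown or untested is made for them only; others in the source may bear on it.

Compound 1 `N#CC1=C(NC(=O)/C=C/c2ccccc2)N(c2ccc(S(N)(=O)=O)cc2)C2=C(C(=O)CCC2)C1c1ccc(Cl)cc1Cl` gives 30% in a functional assay on Ehrlich cells (Mus musculus) for cytotoxicity, read by trypan blue exclusion, with a stated time of 2 h, tested at 25 ug/mL; a higher number here means a stronger effect of the compound at the concentration tested, a lower number a weaker effect. It stands level with compound 3 `NC(=O)C1=C(N)N(c2ccc(S(N)(=O)=O)cc2)C2=C(C(=O)CCC2)C1c1ccc(Cl)cc1Cl`, which gives 30%, the two together being the highest of the three numbers, while compound 2 `COc1cc(C(=O)NC2=C(C#N)C(c3ccc(Cl)cc3Cl)C3=C(CCCC3=O)N2c2ccc(S(N)(=O)=O)cc2)cc(OC)c1OC` gives 20%; the step of a number 10 percentage points lower from compound 1 to compound 2 (within the scatter) lies within the scatter. Compound 4 `CCO/C=N/C1=C(C#N)C(c2ccc(Cl)cc2Cl)C2=C(CCCC2=O)N1c1ccc(S(N)(=O)=O)cc1` differs from compound 1 by a group of 5 heavy atoms (3 carbon, 1 nitrogen, 1 oxygen; no ring) in place of a group of 11 heavy atoms (9 carbon, 1 nitrogen, 1 oxygen; one six-membered aromatic ring of carbon only), on a double-bonded ring carbon. Going by the values given here, the only measured step at the same carbonyl-bearing position is the one from compound 1 to compound 2, and it stayed within the scatter; compound 3 carries a different set of changes, so its value is noted only as level with compound 1. The step of a number 5 percentage points lower from compound 1 to compound 4 (within the scatter) is therefore expected to stay within the scatter. Compound 4 is estimated at 25%, range 10% to 40%.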

Compound 4, a percentage reported as activity, at one concentration (the size of the read-out at that concentration, not a potency): 30%
Compound 4: middle estimate off by 5 percentage points, on the low side; low and high end bracket the measured number.
By their numbers in this assay, from the lowest: compounds 2, 1, 3 and 4 (each within the scatter of the next).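

In this assay, no change at the digits printed from compound 1 to compound 4 (within the scatter), so at this double-bonded ring carbon, the read-out holds when the ((2-phenylethenyl)carbonyl)amino group gives way to a smaller group with no ring and no hydrogen-bond donor. Going by these compounds alone, the earlier step kept a carbonyl and an aromatic ring on this carbon, so this is the first sign that neither is required for this level of effect. No measurement at hand accounts for this result. With every step here within the scatter, this position has yet to show any real change. On these data alone, whether a carboxylic acid or a longer alkyl chain on this carbon would shift the read-out stays open.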